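This account rests on a few compounds, and the source may have more. Where it says the series, first, only, none or still open, it means among the compounds named here.

Compound 2 `C=C1CC[C@@H]2[C@](C)(COC(C)=O)[C@H](OC(C)=O)CC[C@@]2(C)[C@H]1CC(Nc1ccc(S(=O)(=O)Nc2nccs2)cc1)C1=CCOC1=O` gives 4540 nM in a functional assay on IGROV-1 cells (Homo sapiens) for inhibition, read by sulforhodamine B assay, with a stated time of 48 h (on this read-out lower numbers stand for stronger inhibition of growth and higher numbers for weaker inhibition of growth), the highest of the two numbers recorded, and its nearest neighbour is compound 1 `C=C1CC[C@@H]2[C@](C)(COC(C)=O)[C@H](OC(C)=O)CC[C@@]2(C)[C@H]1CC(Nc1ccc(S(=O)(=O)Nc2nccc(C)n2)cc1)C1=CCOC1=O`, which in this assay gives 3620 nM. Compound 3 `C=C1CC[C@@H]2[C@](C)(COC(C)=O)[C@H](OC(C)=O)CC[C@@]2(C)[C@H]1CC(Nc1ccc(S(=O)(=O)Nc2ncccn2)cc1)C1=CCOC1=O` differs from compound 2 by pyrimidin-2-yl in place of 1,3-thiazol-2-yl on a sulfonamide nitrogen. Going by the values given here, the one measured step that bears on this is a 1.3-fold higher number from compound 1 to compound 2 (0.10 log units; within the scatter), another exchange on a sulfonamide nitrogen that stayed within the scatter. A pyrimidin-2-yl entering where a 1,3-thiazol-2-yl leaves is therefore expected to move the number no further than that, so the expected step is a 1.1-fold lower number from compound 2 to compound 3 (0.05 log units; within the scatter). Compound 3 is estimated at 4000 nM, with a range from 2000 nM to 8000 nM.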

Compound 3, concentration for 50% growth inhibition: 2040 nM
Compound 3: the middle estimate sits 2.0-fold (0.29 log units) above what was measured; the range from low to high includes it.
By their numbers in this assay, from the lowest: compounds 3, 1 and 2 (each within the scatter of the next, the first and the last beyond it).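

In this assay the exchange of 1,3-thiazol-2-yl for pyrimidin-2-yl on the sulfonamide nitrogen gives a 2.2-fold lower number from compound 2 to compound 3 (0.35 log units; beyond the scatter) and so, though modest, shows that a change at this position can pass the scatter, which the earlier exchange there did not. Hydrogen in place of methyl on an aromatic carbon gives a 1.8-fold lower number from compound 1 to compound 3 (0.25 log units; within the scatter) and stays within the scatter, so compound 1 and compound 3 cannot be separated here. Nothing available explains the step between the two rings. As far as these compounds go, whether a pyridin-2-yl or an acetyl group on the sulfonamide nitrogen would lower the number further stays open.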